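This account rests on a few compounds, and the source may have more. Where it says the series, first, only, none or still open, it means among the compounds named here.

Measured in a functional assay on HO8910 cells (Homo sapiens) for inhibition, read by MTT assay, with a stated time of 24 h, tested at 1 ug/mL; on this read-out higher numbers stand for more inhibition of growth at the one concentration tested and lower numbers for less inhibition of growth:
- compound 1 `O=C(CCCCC1CCSS1)NO`: "not active" (no number reported)
- compound 2 `O=C(CCCCC(S)CCS)Nc1ccccc1`: 6.38%
- compound 3 `O=C(CCCCC(S)CCS)Nc1ccc(Cl)cc1`: 2.81%

Compound 3 stands at 2.81%, and this number lies within the scatter of compound 2 at 6.38%. The two cannot be ranked against each other. Going by the values given here, compound 1 comes with no number, so it cannot be placed beside them on the scale and gives no step to work from.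

The next compound is compound 4 `O=C(CCCCC(S)CCS)Nc1ccc(F)cc1`, and the change to it is fluoro in place of chloro on an aromatic carbon.

Among the compounds with values here, one measured step bears on this change, namely a number 3.6 percentage points lower from compound 2 to compound 3 (within the scatter), which is chloro in place of hydrogen on an aromatic carbon. That step stays within the scatter, so swapping hydrogen for chloro on this ring left no measurable mark in this assay. Within the data shown here, no fluoro compound has been measured yet, so this single step is the only guide, and it points to no change of note.

The expected step is a number 1.2 percentage points higher from compound 3 to compound 4 (within the scatter), which means none beyond the scatter and no firm direction.

For compound 4 the estimated value is 4%, with an expected range from 0% to 10%.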

Compound 4, percent growth inhibition at one concentration: 12.2%
Compound 4: middle estimate off by 8.2 percentage points, on the low side, and the stated range ends below it.
By their numbers in this assay, from the lowest: compounds 3, 2 and 4 (each within the scatter of the next).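

Chloro to fluoro on the aromatic carbon para to a large group gives a number 9.4 percentage points higher from compound 3 to compound 4 (within the scatter) in this assay and, read against the unsubstituted ring, fluoro in place of hydrogen gives a number 5.8 percentage points higher from compound 2 to compound 4 (within the scatter) on the same read-out. Together with the earlier step of a number 3.6 percentage points lower from compound 2 to compound 3 (within the scatter) on the same ring, these steps mean that hydrogen, chloro and fluoro at this position cannot be ranked, so a second halogen adds a further substituent without separating the series on this read-out. No measurement here bears on what lies behind these numbers.

From the compounds shown here alone, it remains open whether a group of another kind at this position, such as an amine, a methoxy group or a carboxylic acid, would give a step beyond the scatter. Also open, going by these compounds, is whether changes elsewhere on the shared core, such as a longer chain between the carbonyl and the two sulfur-bearing carbons, would move the number more than any halogen swap on this ring has done.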